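One Core, a Longer Chain, and a Smaller Amine

The source may report more compounds than this note shows. Statements on the series, on what has been measured and on what is new or still open speak of the compounds shown alone.

Compound 1 `CCCCCCC(CCO)n1cnc2c(N(C)C)ncnc21` in a functional assay on SW480 cells (Homo sapiens) for antiproliferative activity, read by MTT assay, with a stated time of 48 h (a lower number here means a stronger inhibitor, a higher number a weaker inhibitor), gives > 50000 nM, which is a limit of the measurement rather than a number. Compound 2 `CCCCCCC(CCO)n1cnc2c(N)ncnc21` likewise gives only a limit, > 50000 nM. The change between them, (amino in place of dimethylamino on an aromatic carbon), therefore leaves a step that the two limits leave unreadable from compound 1 to compound 2, because of the limit of > 50000 nM in this assay, at which 2 of the 3 values shown sit. Going by the values given here, compound 3 `CCCCCCCCCCCC(CCO)n1cnc2c(N(C)C)ncnc21` gives 11800 nM in this assay, the only value read as a number; its core differs from that of compound 1 by pentyl in place of hydrogen on a saturated chain carbon, seven bonds along the chain from an aromatic nitrogen, a step of an at least 4.2-fold lower number from compound 1 to compound 3 (0.62 log units; beyond the scatter). Compound 4 `CCCCCCCCCCCC(CCO)n1cnc2c(N)ncnc21`, not yet measured, carries the same change on the core of compound 3: amino in place of dimethylamino on an aromatic carbon. With the earlier step unreadable, the step expected here is a 2.1-fold higher number from compound 3 to compound 4 (0.33 log units; beyond the scatter). Compound 4 is expected to give about 25000 nM, within a wide range from 8000 nM to 60000 nM.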

Compound 4, half-maximal inhibitory concentration: 11600 nM
Compound 4: the middle estimate sits 2.2-fold (0.33 log units) above what was measured; the range from low to high includes it.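

On the core of compound 3 in this assay, amino in place of dimethylamino leaves compound 3 and compound 4 indistinguishable (a 1.0-fold lower number from compound 3 to compound 4 (0.01 log units; within the scatter)). This does not show that the swap makes no difference on every core, since compound 1 and compound 2 each give only a limit, and their step cannot be read, because of this shared ceiling: (the limit of > 50000 nM in this assay, at which 2 of the 4 values shown sit). The pentyl step can be followed on both amine cores (an at least 4.3-fold lower number from compound 2 to compound 4 (0.63 log units; beyond the scatter)), but its size on each remains bounded on one side only: (the same change on two cores in this assay, an at least 4.2-fold lower number (0.62 log units; beyond the scatter) from compound 1 to compound 3 and an at least 4.3-fold lower number (0.63 log units; beyond the scatter) from compound 2 to compound 4; the limit leaves it open whether they differ).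

As far as these compounds go, whether a longer chain would lower the number further remains open. So does what a methylamino group would do on the shared core.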